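This account rests on a few compounds, and the source may have more. Where it says the series, first, only, none or still open, it means among the compounds named here.

Within the data shown here, compound 1 `Fc1ccc(OCc2nn3c(-c4ccncc4)nnc3s2)cc1` is the weaker of the two compounds measured so far. In a functional assay on BHK-21 cells (Mesocricetus auratus) for antiproliferative activity, read by sulforhodamine B assay, with a stated time of 48 h, tested at 100 uM (a lower number here means less inhibition of growth, a higher number more inhibition of growth at the concentration tested), compound 1 gives 52.7%, the lowest of the two numbers in hand, while compound 2 `O=[N+]([O-])c1cccc(C2=Nn3c(nnc3-c3ccncc3)SC2)c1` gives 67.1%, a gap beyond the usual scatter. Compound 3 `Oc1ccc(OCc2nn3c(-c4ccncc4)nnc3s2)cc1` differs from compound 1 by hydroxy in place of fluoro on an aromatic carbon. Among the measured compounds shown here, no comparable step between measured compounds is available, so the change is expected to shift this assay by little, if at all, and the estimated step of a number 2.7 percentage points lower from compound 1 to compound 3 (within the scatter) stays within the scatter. Compound 3 is therefore estimated at 50%, likely between 30% and 70%.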

Compound 3, percent growth inhibition at one concentration: 60.5%
Beside the measured number, compound 3's estimate is 10.5 percentage points below it; the range from low to high includes it.
By their numbers in this assay, from the lowest: compounds 1, 3 and 2 (each within the scatter of the next, the first and the last beyond it).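

Hydroxy in place of fluoro on an aromatic carbon gives a number 7.8 percentage points higher from compound 1 to compound 3 (within the scatter) in this assay, so this position, para to a large group, carries either group without a change that can be told from the scatter. Swapping 4-fluorophenyl for 4-hydroxyphenyl thus brings no readable gain or loss here. No supporting data bear on this result.

As far as these compounds go, whether an amine, a carboxylic acid or a longer chain at this position would move the number remains open. So does whether hydroxy in place of fluoro would read the same on another core.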